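The source may hold more compounds than are shown below. What is called first, only, known or untested is meant among the compounds shown, and "the series" means these compounds.

Compound 3, whose structure is `[SeH]c1nc(NCc2ccccc2)c2ccccc2n1`, sits in a functional assay on HTB-54 cells (Homo sapiens) for cytotoxicity, read by MTT assay, with a stated time of 72 h (a lower number here means a stronger inhibitor of growth, a higher number a weaker inhibitor of growth), not at a number but at a limit of the assay: compound 3 gives > 100000 nM. Its sulfur counterpart, compound 2 `Sc1nc(NCc2ccccc2)c2ccccc2n1`, is likewise recorded only as a limit; in this assay compound 2 gives > 100000 nM. The step from one to the other, a step that the two limits leave unreadable from compound 2 to compound 3, therefore cannot be read in size or direction, since both ends rest on (the limit of > 100000 nM in this assay, at which 3 of the 3 values shown sit). Compound 1 `COc1ccc(CNc2nc([Se]C)nc3ccccc23)cc1`, which carries the methylseleno group together with a methoxy on the benzyl ring, is also known only as a limit; in this assay compound 1 gives > 100000 nM.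

Compound 4 `C[Se]c1nc(NCc2ccccc2)c2ccccc2n1` differs from compound 3 by methyl in place of hydrogen on a selenium. Among the measured compounds shown here, no measured step bears directly on this change, and the one step that exists, from compound 2 to compound 3, is itself unreadable. With all three known values standing at the same limit, no movement beyond the scatter is expected from compound 3 to compound 4, so that a step that the limit leaves unreadable from compound 3 to compound 4 is the estimated step. Compound 4 is therefore expected to give about 150000 nM in this assay, within a range from 60000 nM to 400000 nM, most likely reported again only as a limit.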

Compound 4, concentration for total growth inhibition: > 100000 nM
Compound 4: no number, only a limit; the forecaster's own chance of this, stated with the estimate: 80%; the middle value does not contradict the limit.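

Among the compounds shown here, compound 4 is recorded only as a limit, so no step linking it to compound 1, compound 2 or compound 3 can be read: the limit of > 100000 nM in this assay, at which 4 of the 4 values shown sit. The compounds shown leave open which change to the shared core, if any, would give a measurable value in this assay.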